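Nitro in place of hydrogen: expecting compound 3

The compounds below may be only part of what the source reports. "The series", "measured", "known", "first", "only" and "open" are said of these compounds alone.

Compound 1 `c1ccc(Oc2ncnc3[nH]ccc23)cc1` is the starting point. Among the compounds with values here, in an assay on HEK293-TREx cells for antagonist activity at transient receptor potential cation channel subfamily A member 1 (Homo sapiens), read by fluorescence and calcium flux, with a stated time of 72 h (a lower number here means a stronger inhibitor, a higher number a weaker inhibitor), compound 1 gives 3200 nM, which is the only plain number available. Compound 2 `Cc1ccccc1Oc1ncnc2[nH]ccc12` differs from compound 1 by a methyl in place of hydrogen on an aromatic carbon. In this assay compound 2 reaches only the limit of > 32000 nM. That single change gave an at least 10-fold higher number from compound 1 to compound 2 (1.00 log units; beyond the scatter), resting on (the limit of > 32000 nM in this assay, at which 1 of the 2 values shown sits). Compound 3 `O=[N+]([O-])c1ccc(Oc2ncnc3[nH]ccc23)cc1` is not yet measured; it carries nitro in place of hydrogen on an aromatic carbon. Within the data shown here, the only measured step bearing on it is the methyl step, which weakened inhibition beyond the scatter, so a substituent on the same ring may be expected to raise the number as well, although a nitro group is a different kind of addition and the size of the effect is uncertain. For compound 3 the expected step is a 2.2-fold higher number from compound 1 to compound 3 (0.34 log units; beyond the scatter). The estimate for compound 3 is 7000 nM, within 2000 nM to 32000 nM.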

Compound 3, half-maximal inhibitory concentration: > 32000 nM
Compound 3: no number, only a limit (the forecaster's own chance of this, stated with the estimate: 30%); middle value at least 4.5-fold (0.66 log units) from the limit.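

In this assay compound 3 gives > 32000 nM, which is a limit of the assay and not a number. The nitro group, on a six-membered aromatic ring of carbon only and para to a large group, gives an at least 10-fold higher number from compound 1 to compound 3 (1.00 log units; beyond the scatter), so the loss of inhibition on this ring is no longer tied to methyl alone: a second, quite different group also weakens compound 1 beyond the scatter. How large either loss really is cannot be told, because the readings stop at the same ceiling: the limit of > 32000 nM in this assay, at which 2 of the 3 values shown sit.

Going by these compounds, whether a fluorine atom, an amine or a carboxylic acid at this same place would keep the value that compound 1 gives, 3200 nM, stays open. Also open, on these data alone, is whether the nitro group would weaken inhibition as strongly elsewhere on the ring.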